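The source may report more compounds than this note shows. Statements on the series, on what has been measured and on what is new or still open speak of the compounds shown alone.

Measured so far in a functional assay on RPMI-8226 cells (Homo sapiens) for inhibition, read by sulforhodamine B assay, with a stated time of 48 h; on this read-out lower numbers stand for stronger inhibition of growth and higher numbers for weaker inhibition of growth:
- compound 1 `O=C(Cc1csc2nc(-c3ccc(Br)cc3)cn12)N/N=C/c1ccc(O)cc1`: 39800 nM
- compound 2 `COc1cccc(OC)c1/C=N/NC(=O)Cc1csc2nc(-c3ccc(Br)cc3)cn12`: > 100000 nM

The reading for compound 2, > 100000 nM, is a limit of the assay and not a number. It marks (the limit of > 100000 nM in this assay, at which 1 of the 2 values shown sits).

Compound 3 `O=C(Cc1csc2nc(-c3ccc(Br)cc3)cn12)N/N=C/c1ccc(Cl)cc1Cl` is the next analogue, with 2,4-dichlorophenyl in place of 2,6-dimethoxyphenyl on a carbon with a double bond to nitrogen.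

Going by the values given here, one measured step bears on this place: an at least 2.5-fold higher number from compound 1 to compound 2 (0.40 log units; beyond the scatter). It shows that the read-out responds to the group exchanged here, but neither compound carries the incoming group, so its guidance is loose. Among the compounds with values here, compound 1 gives 39800 nM, the only number available, so a modest move to a lower number is expected in this assay. A reading at the limit also remains possible for compound 3.

The expected step is an at least 2.0-fold lower number from compound 2 to compound 3 (0.30 log units; that floor lies within the scatter).

For compound 3 the estimated value is 50000 nM, with an expected range of 18000 nM to 100000 nM.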

Compound 3, concentration for total growth inhibition: > 100000 nM
Compound 3: no number, only a limit (the forecaster's own chance of this, stated with the estimate: 35%); middle value at least 2.0-fold (0.30 log units) from the limit.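

In this assay, compound 3 gives > 100000 nM, which is a limit and not a number. Thus 2,4-dichlorophenyl, like 2,6-dimethoxyphenyl, fails to retain the measurable reading seen with 4-hydroxyphenyl: the exchange gives an at least 2.5-fold higher number from compound 1 to compound 3 (0.40 log units; beyond the scatter), so a second, different replacement on this carbon with a double bond to nitrogen moves the read-out the same way. The step from compound 2 to compound 3 cannot be read because both readings rest on one limit: the limit of > 100000 nM in this assay, at which 2 of the 3 values shown sit.

The compounds shown do not separate the loss of the hydroxy group from the arrival of the new groups on the ring. Also open, going by these compounds, is whether a phenyl ring carrying an amine or a carboxylic acid in place of that hydroxy group would stay close to compound 1 at 39800 nM.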